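Swapping the aryl group in a cinnamate ester series

The compounds below may be only part of what the source reports. "The series", "measured", "known", "first", "only" and "open" are said of these compounds alone.

Measured compounds in a functional assay on the whole organism (strain Kunming) with Mus musculus as the target, with a stated time of 0.5 h, at a dose of 300 mg/kg by the intraperitoneal route; on this read-out higher numbers stand for a weaker effect at the one dose given and lower numbers for a stronger effect:
compound 1 `COc1ccccc1/C=C/C(=O)OC/C=C/c1cc(OC)c(OC)cc1OC`: 100%
compound 2 `COc1cccc(/C=C/C(=O)OC/C=C/c2cc(OC)c(OC)cc2OC)c1`: 75%
compound 3 `COc1cc(OC)c(OC)cc1/C=C/COC(=O)/C=C/c1ccccc1C(F)(F)F`: 75%

Compound 3 stands level with compound 2, since no change at the digits printed from compound 2 to compound 3 (within the scatter), and both stand apart from compound 1, since a number 25 percentage points lower from compound 1 to compound 3 (beyond the scatter) and a number 25 percentage points lower from compound 1 to compound 2 (beyond the scatter). Compound 4 `COc1cc(OC)c(OC)cc1/C=C/COC(=O)/C=C/c1ccc(Br)cc1` has not been measured. The change from compound 3 to compound 4 is 4-bromophenyl in place of 2-(trifluoromethyl)phenyl on a double-bonded chain carbon bound to a double-bonded chain carbon. Among the compounds with values here, the only measured exchange of a whole group at that place within the scatter is the one from compound 2 to compound 3, while the exchange from compound 1 to compound 2 was modest. Within the data shown here, no measured compound carries 4-bromophenyl, so the expectation stays near compound 3: compound 4 is expected to give 78%, within 60% to 100%, which means a step of a number 3 percentage points higher from compound 3 to compound 4 (within the scatter), expected to lie within the scatter.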

Compound 4, a percentage reported as activity, at one dose (the size of the read-out at that dose, not a potency): 75%
For compound 4 the middle estimate is 3 percentage points above the measured one; low and high end bracket the measured number.
By their numbers in this assay, from the lowest: compounds 2, 3 and 4 (each within the scatter of the next); then compound 1.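

In this assay there is no change at the digits printed from compound 3 to compound 4 (within the scatter) and no change at the digits printed from compound 2 to compound 4 (within the scatter), so 4-bromophenyl reads like 2-(trifluoromethyl)phenyl and 3-methoxyphenyl at this place, even though it has fewer heavy atoms than 2-(trifluoromethyl)phenyl. With a number 25 percentage points lower from compound 1 to compound 4 (beyond the scatter) as well, compound 1 with its 2-methoxyphenyl remains the only one of the four set apart. Nothing available explains this result.

The compounds shown leave open whether a phenyl ring carrying an amine or a carboxylic acid at this place would read like compounds 2, 3 and 4. They also leave open whether an unsubstituted phenyl would do so.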